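The compounds below may be only part of what the source reports. "The series", "measured", "known", "first", "only" and "open" are said of these compounds alone.

Measured so far in a functional assay on HTB-54 cells (Homo sapiens) for cytotoxicity, read by MTT assay, with a stated time of 72 h; a lower number here means a stronger inhibitor of growth, a higher number a weaker inhibitor of growth:
compound 1 `CCCCC[Se]c1nc(NCc2ccc(SC)cc2)c2ccccc2n1` — 81300 nM
compound 3 `Nc1nc([SeH])nc2ncccc12` — 96600 nM
compound 2 `CSc1ccc(CNc2nc([SeH])nc3ccccc23)cc1` — a limit of this assay, > 100000 nM

Compound 1 and compound 3 lie within the scatter of each other in this assay. The difference between the core of compound 2 and the core of compound 3 is not broken down here. The change from compound 2 to compound 1 is pentyl in place of hydrogen on a selenium. It made an at least 1.2-fold lower number from compound 2 to compound 1 (0.08 log units; that floor lies within the scatter), a floor set by the limit of > 100000 nM in this assay, at which 1 of the 3 values shown sits. Compound 4 `CCCCC[Se]c1nc(N)c2cccnc2n1`, not yet measured, carries the same change on compound 3: pentyl in place of hydrogen on a selenium. The earlier step rests on a limit, so only its floor is known. A step of about that floor or somewhat larger is expected, a 1.6-fold lower number from compound 3 to compound 4 (0.21 log units; within the scatter). Compound 4 is estimated at 60000 nM, between 20000 nM and 150000 nM.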

Compound 4, concentration for total growth inhibition: 51000 nM
Beside the measured number, compound 4's estimate is 1.2-fold (0.07 log units) above it, within the range that was stated.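

In this assay, pentyl in place of hydrogen on a selenium gives a 1.9-fold lower number from compound 3 to compound 4 (0.28 log units; within the scatter). Neither this step nor the earlier one lies beyond the scatter, so the notes cannot tell whether the two cores respond alike: the same change on two cores in this assay, an at least 1.2-fold lower number (0.08 log units; that floor lies within the scatter) from compound 2 to compound 1 and a 1.9-fold lower number (0.28 log units; within the scatter) from compound 3 to compound 4; the limit leaves it open whether they differ. The series therefore does not show that the change carries a real or fixed effect from one core to the other, and compound 2 stands at a limit rather than a number: the limit of > 100000 nM in this assay, at which 1 of the 4 values shown sits.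

The compounds shown leave open whether a shorter chain, a longer chain or a benzyl group on the selenium would give a step beyond the scatter. They also leave open what a carboxylic acid or an amine at the end of such a chain would do.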